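Nitrogen substituent change carried onto the disulfide-bearing amide

The source may report more compounds than this note shows. Statements on the series, on what has been measured and on what is new or still open speak of the compounds shown alone.

Of the compounds shown here, three have been measured. Compound 1 `Cn1c(=O)c(C(=O)NCCN)c(O)c2ccccc21` carries a methyl on the aromatic nitrogen and a (2-aminoethyl)carbamoyl group on the shared core; compound 2 `NCCNC(=O)c1c(O)c2ccccc2n(-c2ccccc2)c1=O` differs from it by the change (phenyl in place of methyl on an aromatic nitrogen). Compound 3 `Cn1c(=O)c(C(=O)NCCCCCCNC(=O)CCCCC2CCSS2)c(O)c2ccccc21` carries the methyl on the aromatic nitrogen as compound 1 does, but its amide chain is much longer and ends in a disulfide-containing ring; the difference between the two cores is not broken down here.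

In a functional assay, with a stated time of 20 min, tested at 0.5 mM (a higher number here means a stronger effect of the compound at the concentration tested, a lower number a weaker effect), compound 1 gives 20.9%. In this assay compound 2 gives 1.4%, a step of a number 19.5 percentage points lower from compound 1 to compound 2 (beyond the scatter). In this assay compound 3 gives 28.4%, which lies within the scatter of compound 1 and beyond it from compound 2.

Compound 4 `O=C(CCCCC1CCSS1)NCCCCCCNC(=O)c1c(O)c2ccccc2n(-c2ccccc2)c1=O` is not yet measured. It differs from compound 3 by phenyl in place of methyl on an aromatic nitrogen. This is the same kind of change as from compound 1 to compound 2, though not the same: the place is meta to a (2-aminoethyl)carbamoyl group in the pair of compound 1 and compound 2, and meta to a large group in the pair of compound 3 and compound 4. The single earlier occurrence of this change is the only basis for an expectation.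

On that basis a step of a number 19.4 percentage points lower from compound 3 to compound 4 (beyond the scatter) in this assay is expected for compound 4, because the same change gave a number 19.5 percentage points lower from compound 1 to compound 2 (beyond the scatter). In this assay compound 4 is estimated at 9%, with a likely range from 0% to 25%.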

Compound 4, a percentage reported as activity, at one concentration (the size of the read-out at that concentration, not a potency): 23.9%
For compound 4 the middle estimate is 14.9 percentage points below the measured one; the measured number falls inside the stated range.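

In this assay, phenyl in place of methyl on an aromatic nitrogen does not carry the same step from one core to the other: the same change on two cores in this assay, a number 19.5 percentage points lower (beyond the scatter) from compound 1 to compound 2 and a number 4.5 percentage points lower (within the scatter) from compound 3 to compound 4, 15 percentage points apart, beyond the scatter of two such steps

On the disulfide-bearing amide the step is a number 4.5 percentage points lower from compound 3 to compound 4 (within the scatter), so this pair cannot be told apart in this read-out, and the large drop seen on the (2-aminoethyl)carbamoyl pair is not a fixed increment to transfer across the series. This does not show what sets the two steps apart, since the long amide chain and the disulfide-containing ring sit together in the large group, and two pairs read at a single concentration give neither a general rule nor a comparison of potency.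

As far as these compounds go, it remains open whether the phenyl step follows the chain length or the disulfide-containing ring, which a long chain ending in a simple amine, or a short chain carrying that same ring, would help to separate. Also open, from the compounds shown here alone, is how the two amide types respond to other groups on the aromatic nitrogen, such as ethyl or benzyl, which would show whether phenyl behaves differently from other replacements for methyl.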